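A few compounds are considered here, and "the series" means these few. Any claim that something is new, unique, unknown or untested is made for them only; others in the source may bear on it.

Compound 2, `Cc1nc2c(OCc3ccccc3)cccn2c1/N=C/N(C)C`, gives 9.8 mg/kg in a functional assay on the whole organism with Rattus norvegicus as the target; a higher number here means that more compound is needed for the effect, a lower number that less compound is needed. Going by the values given here, it stands alongside the only other measured compound, compound 1, `CCCCc1nc2c(OCc3ccccc3)cccn2c1N`, which in this assay gives 7.5 mg/kg; the gap between the two lies within the usual scatter, so they cannot be told apart. Compound 3, `CCCN(CCC)c1c(C)nc2c(OCc3ccccc3)cccn12`, is not yet measured. It differs from compound 2 in one place: a group of 7 heavy atoms (6 carbon, 1 nitrogen; no ring) in place of a group of 5 heavy atoms (3 carbon, 2 nitrogen; no ring), on an aromatic carbon. Among the compounds with values here, no measured pair shows what such a change does here, so no step beyond the scatter is expected in either direction. Compound 3 is therefore estimated at 10 mg/kg, with a range from 3 mg/kg to 30 mg/kg. The expected step is a 1.0-fold higher number from compound 2 to compound 3 (0.01 log units; within the scatter).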

Compound 3, dose for half-maximal effect: 8.4 mg/kg
For compound 3 the middle estimate is 1.2-fold (0.08 log units) above the measured one, within the range that was stated.
By their numbers in this assay, from the lowest: compounds 1, 3 and 2 (each within the scatter of the next).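

At this aromatic carbon, dipropylamino takes the place of the group in compound 2 in this assay with a step that stays within the scatter (a 1.2-fold lower number from compound 2 to compound 3 (0.07 log units; within the scatter)). This first pair differing in one place shows that the position tolerates a swap to a group of 7 heavy atoms with no readable effect on the dose needed. No measured evidence bears on the reason. On these data alone, whether a piperidine ring or a carboxylic acid on this carbon would also stay within the scatter remains open.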